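Lengthening the chain of an amino alcohol antiproliferative

A few compounds are considered here, and "the series" means these few. Any claim that something is new, unique, unknown or untested is made for them only; others in the source may bear on it.

Compound 1 `CCCCCCCCCCCCCCC[C@@H](O)[C@@H](N)C(C)C` gives 7200 nM in a functional assay on SW1573 cells (Homo sapiens) for antiproliferative activity, read by sulforhodamine B assay, with a stated time of 48 h; a higher number here means a weaker inhibitor of growth, a lower number a stronger inhibitor of growth.
Compound 2 `CCCCCCCCC[C@@H](O)[C@H](C)N` gives 9500 nM in this assay.

Compound 2 has the higher of the two numbers, yet its gap to compound 1 lies within the scatter, so the two compounds cannot be told apart here. Compound 3 `CCCCCCCCCCCCCCC[C@@H](O)[C@H](C)N` differs from compound 2 by a single change: hexyl in place of hydrogen on a saturated chain carbon, ten or more bonds along the chain from an oxygen on a saturated carbon. For the measured compounds named here, no measured pair isolates this change, and compound 1 carries a different group, so it is not a matching comparison. The step of a 1.6-fold lower number from compound 2 to compound 3 (0.20 log units; within the scatter) is therefore expected to be small, a modest gain at most. Compound 3 is estimated at 6000 nM, with a range from 2000 nM to 18000 nM.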

Compound 3, concentration for 50% growth inhibition: 1300 nM
The estimate for compound 3 lay 4.6-fold (0.66 log units) above the measured number; the measured number lies below the stated range.
By their numbers in this assay, from the lowest: compound 3; then compounds 1 and 2 (each within the scatter of the next).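

In this assay the step for hexyl in place of hydrogen on a saturated chain carbon, ten or more bonds along the chain from an oxygen on a saturated carbon, is a 7.3-fold lower number from compound 2 to compound 3 (0.86 log units; beyond the scatter) and shows that this place affects growth inhibition, which compounds 1 and 2 alone could not show. Methyl in place of isopropyl on a saturated chain carbon bound to an amine nitrogen and a saturated chain carbon also counts, with a 5.5-fold lower number from compound 1 to compound 3 (0.74 log units; beyond the scatter) beyond the scatter. Nothing at hand explains either step.

For the compounds shown here, still open is whether a longer chain than the one in compound 3 would lower the number further. Also open, on these data alone, is how ethyl would compare with methyl on the carbon bound to the amine nitrogen.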